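A further ethyl on the aryl-triazole of compound 2

The source may hold more compounds than are shown below. What is called first, only, known or untested is meant among the compounds shown, and "the series" means these compounds.

Compound 2 `CCc1cccc(C)c1-n1nncc1CN1C(=O)C2(C(C#N)=C(N)Oc3c(N)cc4nc5ccccc5nc4c32)c2ccccc21` gives only a limit of the assay in a functional assay on A549 cells (Homo sapiens) for antiproliferative activity, read by MTT assay, with a stated time of 48 h (a lower number here means a stronger inhibitor, a higher number a weaker inhibitor), > 50000 nM, so its potency is known merely as a bound, not a number (the limit of > 50000 nM in this assay, at which 1 of the 2 values shown sits). Compound 1 `N#CC1=C(N)Oc2c(N)cc3nc4ccccc4nc3c2C12C(=O)N(Cc1cnnn1-c1cccc(Br)c1)c1ccccc12` gives 18900 nM in this assay. Compound 3 `CCc1cccc(CC)c1-n1nncc1CN1C(=O)C2(C(C#N)=C(N)Oc3c(N)cc4nc5ccccc5nc4c32)c2ccccc21` differs from compound 2 by methyl in place of hydrogen on a saturated chain carbon bound to an aromatic carbon, reading further out as 2-ethyl-6-methylphenyl to 2,6-diethylphenyl. Going by the values given here, the only measured step, an at least 2.6-fold higher number from compound 1 to compound 2 (0.42 log units; beyond the scatter), already moved toward the limit. Compound 3 is therefore expected to stay at or beyond the limit, an estimated step that the limit leaves unreadable from compound 2 to compound 3. For compound 3 the estimate is 70000 nM, within 25000 nM to 200000 nM.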

Compound 3, half-maximal inhibitory concentration: > 50000 nM
Compound 3: only a limit was reported; the forecaster's own chance of this, stated with the estimate: 75%; the middle value is on the limit's open side.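

With compound 3 as well as compound 2 resting on a limit in this assay, the change from methyl to ethyl on this aryl group cannot be read. Placing 2,6-diethylphenyl on the aromatic nitrogen in place of 3-bromophenyl gives an at least 2.6-fold higher number from compound 1 to compound 3 (0.42 log units; beyond the scatter), so a second such replacement also exceeds the scatter, and compound 1 alone keeps a readable value. The results at this position now gather at one bound: the limit of > 50000 nM in this assay, at which 2 of the 3 values shown sit.

As far as these compounds go, how far compound 2 and compound 3 lie past that limit remains open. So does whether an aminophenyl or carboxyphenyl group on the aromatic nitrogen would give a readable value.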